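A few compounds are considered here, and "the series" means these few. Any claim that something is new, unique, unknown or untested is made for them only; others in the source may bear on it.

Measured compounds in a functional assay on FM3A cells (Mus musculus) for antiproliferative activity; on this read-out lower numbers stand for stronger inhibition and higher numbers for weaker inhibition:
- compound 1, `COc1cc(C(=O)c2sc(-c3ccc(Cl)cc3)cc2N)cc(OC)c1OC`: 90 nM
- compound 2, `COc1cc(C(=O)c2sc(-c3ccc(C(F)(F)F)cc3)cc2N)cc(OC)c1OC`: 540 nM
- compound 3, `COc1cc(C(=O)c2sc(-c3ccc(I)cc3)cc2N)cc(OC)c1OC`: 420 nM

Compound 3 gives the second highest of the three numbers in this assay. Its nearest neighbour is compound 2, and the two lie within the scatter of each other: a 1.3-fold lower number from compound 2 to compound 3 (0.11 log units; within the scatter). Its furthest neighbour is compound 1: a 4.7-fold higher number from compound 1 to compound 3 (0.67 log units; beyond the scatter). The remaining step, a 6.0-fold higher number from compound 1 to compound 2 (0.78 log units; beyond the scatter), separates compound 1 from compound 2 by a similar margin.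

Compound 4, `COc1cccc(-c2cc(N)c(C(=O)c3cc(OC)c(OC)c(OC)c3)s2)c1`, has not yet been measured. It differs from compound 3 in one place: 3-methoxyphenyl in place of 4-iodophenyl on an aromatic carbon. All three measured steps exchange chloro, trifluoromethyl and iodo among themselves on the same kind of phenyl group; none removes a group of that kind altogether, and none introduces a methoxy. They therefore bear on the present step only loosely, showing that such exchanges move this assay by modest amounts, not more. Among the measured compounds shown here, with no direct precedent, the expectation for compound 4 is a number near that of compound 3 or somewhat higher, with a wide range. Compound 4 is estimated at 600 nM in this assay, between 150 nM and 2500 nM. That estimate corresponds to an expected step of a 1.4-fold higher number from compound 3 to compound 4 (0.15 log units; within the scatter).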

Compound 4, half-maximal inhibitory concentration: 36 nM
Estimate against measurement, compound 4: 17-fold (1.22 log units) above; the measured number lies below the stated range.
By their numbers in this assay, from the lowest: compound 4; then compound 1; then compounds 3 and 2 (each within the scatter of the next).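

In this assay, among the compounds shown here, on the aromatic carbon next to the ring sulfur, 3-methoxyphenyl gives the largest steps so far (a 12-fold lower number from compound 3 to compound 4 (1.07 log units; beyond the scatter); a 15-fold lower number from compound 2 to compound 4 (1.18 log units; beyond the scatter)), whereas exchanges among the chloro, trifluoromethyl and iodo groups moved the number only modestly. For the compounds shown here, the step from the best of the earlier compounds is smaller but still clear (a 2.5-fold lower number from compound 1 to compound 4 (0.40 log units; beyond the scatter)), which makes compound 4 the most potent of the four and shows that this position can give more than the earlier groups suggested. Nothing available accounts for the gain.

Whether the gain follows the methoxy itself or its place on the phenyl stays open, as every other phenyl shown carries its group in the 4-position. Also open, on these data alone, is how an unsubstituted phenyl, or an ethoxy or an amine on that phenyl, would read in this assay.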